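The source may report more compounds than this note shows. Statements on the series, on what has been measured and on what is new or still open speak of the compounds shown alone.

Measured compounds:
- compound 1 `O=C(CSc1nc(Nc2ccccc2)c2ccccc2n1)Nc1cccc(F)c1`: 15600 nM
- compound 2 `O=C(CSc1nc(Nc2ccccc2)c2ccccc2n1)Nc1cccc(Cl)c1`: 12600 nM
- compound 3 `C=CC(=O)Nc1cccc(NC(=O)CSc2nc(Nc3cccc(F)c3)c3ccccc3n2)c1`: 5370 nM

In a functional assay on PC-3 cells (Homo sapiens) for inhibition, read by MTT assay, with a stated time of 72 h (a higher number here means a weaker inhibitor, a lower number a stronger inhibitor), compound 1 gives 15600 nM, while compound 2 gives 12600 nM. The only difference between the two is chloro in place of fluoro on an aromatic carbon, and it produced a 1.2-fold lower number from compound 1 to compound 2 (0.09 log units; within the scatter). Compound 3 carries a different core; the difference between its core and the core of compound 1 is not broken down here. In this assay compound 3 gives 5370 nM, the lowest of the three numbers, and its gap to compound 2 and to compound 1 lies beyond the scatter in each case.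

Compound 4 `C=CC(=O)Nc1cccc(NC(=O)CSc2nc(Nc3cccc(Cl)c3)c3ccccc3n2)c1` has not yet been measured. It differs from compound 3 by chloro in place of fluoro on an aromatic carbon, the same change as between compound 1 and compound 2, at the same kind of place on the same kind of ring.

Going by the values given here, only one prior instance of this change is available. The expected step is a 1.2-fold lower number from compound 3 to compound 4 (0.08 log units; within the scatter), because the earlier step of a 1.2-fold lower number from compound 1 to compound 2 (0.09 log units; within the scatter) lay within the scatter. Compound 4 is therefore expected at about 4500 nM. For compound 4 the expected range runs from 2200 nM to 9500 nM.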

Compound 4, half-maximal inhibitory concentration: 12300 nM
Beside the measured number, compound 4's estimate is 2.7-fold (0.44 log units) below it; the whole stated range lies below it.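

In this assay, the change from 3-fluorophenyl to 3-chlorophenyl gives a 2.3-fold higher number from compound 3 to compound 4 (0.36 log units; beyond the scatter), so on the core of compound 3 the swap carries a step beyond the scatter. The step on the core of compound 1 lay within the scatter, and the two cores do not respond alike to this change: the same change on two cores in this assay, a 1.2-fold lower number (0.09 log units; within the scatter) from compound 1 to compound 2 and a 2.3-fold higher number (0.36 log units; beyond the scatter) from compound 3 to compound 4, 2.8-fold (0.45 log units) apart, beyond the scatter of two such steps This rests on a single pair for each core, so it shows that the step from one core cannot be carried to the other in this series, but it gives no reason for the difference and no general rule for either core.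

The compounds shown hold only fluoro and chloro as the halogen, so it remains open how bromo, methyl, methoxy or an unsubstituted phenyl would behave at this place on the core of compound 3. Also open, going by these compounds, is whether the result depends on the acrylamide, since a saturated propanamide in its place would test whether the difference between cores survives without the carbon-carbon double bond.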